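Replacing a Carbamoylpiperazine by an Aminopiperidine

A few compounds are considered here, and "the series" means these few. Any claim that something is new, unique, unknown or untested is made for them only; others in the source may bear on it.

Compound 2 `NC(=O)N1CCN(C2CN(CCC3(c4ccc(Cl)c(Cl)c4)CCC(=O)N(CC4CC4)C3)C2)CC1` gives 5.01 nM in an assay on isolated protein (artery, Oryctolagus cuniculus) with Substance-P receptor (Homo sapiens) as the target (a higher number here means weaker binding, a lower number tighter binding), the highest of the two numbers at hand; its nearest neighbour is compound 1 `CNS(=O)(=O)N1CCN(C2CN(CCC3(c4ccc(Cl)c(Cl)c4)CCC(=O)N(CC4CC4)C3)C2)CC1`, which gives 3.16 nM. Among the measured compounds shown here, the only measured step, a 1.6-fold higher number from compound 1 to compound 2 (0.20 log units; within the scatter), exchanges the group on the ring nitrogen and stays within the scatter. Compound 3 `NC1CCN(C2CN(CCC3(c4ccc(Cl)c(Cl)c4)CCC(=O)N(CC4CC4)C3)C2)CC1` differs from compound 2 by 4-aminopiperidin-1-yl in place of 4-carbamoylpiperazin-1-yl on a saturated ring carbon. For the measured compounds named here, this exchange reaches further than the one measured step, as it replaces the whole six-membered ring rather than only the group on its nitrogen, so that step bears on it only loosely. What it does show is that one exchange at this end of the molecule passed without a shift beyond the scatter. A step of a 1.2-fold higher number from compound 2 to compound 3 (0.08 log units; within the scatter) is therefore expected, one that may well stay within the scatter. The estimate for compound 3 in this assay is 6 nM, with a range from 2 nM to 20 nM.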

Compound 3, dissociation constant: 2 nM
Compound 3: the middle estimate sits 3.0-fold (0.48 log units) above what was measured; low and high end bracket the measured number.
By their numbers in this assay, from the lowest: compounds 3, 1 and 2 (each within the scatter of the next, the first and the last beyond it).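

In this assay, among the compounds shown here, the whole ring on the saturated ring carbon can be exchanged without loss of binding: a 2.5-fold lower number from compound 2 to compound 3 (0.40 log units; beyond the scatter) is the first step in this set that lies beyond the scatter, though it is a modest one. The reference matters, however, as a 1.6-fold lower number from compound 1 to compound 3 (0.20 log units; within the scatter) stays within the scatter, so 4-aminopiperidin-1-yl stands clearly apart from only one of the two substituted piperazines. Nothing at hand explains the difference between these two readings.

The compounds shown leave open whether the amine on the piperidine ring is itself needed, which a 4-hydroxypiperidin-1-yl or an unsubstituted piperidin-1-yl at the same carbon would address. They also leave open how a 4-(dimethylamino)piperidin-1-yl or a carboxylic acid on that ring would fare.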